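A few compounds are considered here, and "the series" means these few. Any claim that something is new, unique, unknown or untested is made for them only; others in the source may bear on it.

In a functional assay on J774.A1 cells (Mus musculus) for inhibition, read by Griess assay, with stated times of 1 h and 24 h (on this read-out lower numbers stand for stronger inhibition and higher numbers for weaker inhibition), the series so far reads:
- compound 1 `O=C1CC(c2ccccc2OCc2ccc(F)cc2)Oc2ccccc21` gives 25500 nM
- compound 2 `CCCCCOc1ccccc1C1CC(=O)c2ccccc2O1` gives 39300 nM

Compound 2 is the higher of the two numbers, but it lies within the scatter of compound 1, so the two cannot be ranked. Compound 3 `COc1ccccc1C1CC(=O)c2ccccc2O1` carries methoxy in place of the pentyloxy of compound 2 (hydrogen in place of butyl on a saturated chain carbon bound to an oxygen on an aromatic ring), that is, hydrogen in place of butyl on a saturated chain carbon bound to an oxygen on an aromatic ring. Among the measured compounds shown here, only one measured step bears on this place, a 1.5-fold higher number from compound 1 to compound 2 (0.19 log units; within the scatter), and it stayed within the scatter. For the measured compounds named here, no measured step shortens the chain to methoxy, so this support is indirect and the range stays wide. The expected change, a 1.0-fold higher number from compound 2 to compound 3 (0.01 log units; within the scatter), is none beyond the scatter in this assay. For compound 3 the estimated value is 40000 nM (expected range 15000 nM to 100000 nM).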

Compound 3, half-maximal inhibitory concentration: 44500 nM
The estimate for compound 3 lay 1.1-fold (0.05 log units) below the measured number, within the range that was stated.
By their numbers in this assay, from the lowest: compounds 1, 2 and 3 (each within the scatter of the next).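

Pentyloxy to methoxy, the first direct comparison of two chain lengths here, gives a 1.1-fold higher number from compound 2 to compound 3 (0.05 log units; within the scatter) in this assay at the place on a saturated chain carbon bound to an oxygen on an aromatic ring. Hydrogen in place of 4-fluorophenyl at that same place gives a 1.7-fold higher number from compound 1 to compound 3 (0.24 log units; within the scatter) and also stays within the scatter. Butyl, 4-fluorophenyl and hydrogen therefore cannot be told apart at this place, and none of the three can be ranked on these numbers. Nothing available offers an explanation for this flat result.

As far as these compounds go, whether any group at this place can shift the number beyond the scatter remains open, for instance an amine or a carboxylic acid at the chain end, or a chain longer than pentyl. From the compounds shown here alone, the effect of groups elsewhere on the shared core also remains open.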